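Changing the Aromatic Group of Compound 2

The source may report more compounds than this note shows. Statements on the series, on what has been measured and on what is new or still open speak of the compounds shown alone.

Of the compounds shown here, three sharing one core have been measured in a functional assay on MCF7 cells (Homo sapiens) for inhibition, read by sulforhodamine B assay, with a stated time of 48 h, tested at 50 uM; a higher number here means more inhibition of growth at the concentration tested, a lower number less inhibition of growth. Compound 2 `COc1ccc([C@@H]2C/C(=N/OCc3cn(-c4cccc(CO)c4)nn3)c3cc(CC=C(C)C)c(OC)cc3O2)cc1` gives 42%. Compound 1 `COc1ccc([C@@H]2C/C(=N/OCc3cn(-c4ccc(C(=O)c5ccccc5)cc4)nn3)c3cc(CC=C(C)C)c(OC)cc3O2)cc1` gives 41%, level with compound 2 within the scatter. Compound 3 `COc1ccc([C@@H]2C/C(=N/OCc3cn(-c4ccc(NC(=O)c5ccccc5)cc4)nn3)c3cc(CC=C(C)C)c(OC)cc3O2)cc1` gives 4%, beyond the scatter from both of the others. Compound 2 therefore stands in the upper pair of these numbers.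

The next compound, compound 4 `COc1ccc([C@@H]2C/C(=N/OCc3cn(-c4cccnc4Cl)nn3)c3cc(CC=C(C)C)c(OC)cc3O2)cc1`, keeps the core and differs from compound 2 in one group: 2-chloropyridin-3-yl in place of 3-(hydroxymethyl)phenyl on an aromatic nitrogen. Here 2-chloropyridin-3-yl stands in place of 3-(hydroxymethyl)phenyl, on an aromatic nitrogen of a five-membered aromatic ring with 3 nitrogen.

For the measured compounds named here, only one measured step changes the group carried on that nitrogen: a number 37 percentage points lower from compound 1 to compound 3 (beyond the scatter), which is large and comes with benzamido in place of benzoyl on an aromatic carbon. Going by the values given here, that step is a different exchange from this one, so it shows only that a change in this group can move the number far. Among the compounds with values here, no measured compound carries 2-chloropyridin-3-yl. A modest fall in this assay is expected, near the edge of the scatter and much smaller than that large step. The expected step is a number 12 percentage points lower from compound 2 to compound 4 (beyond the scatter). For compound 4 the estimated value is 30%, with an expected range from 8% to 50%.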

Compound 4, percent growth inhibition at one concentration: 35%
The estimate for compound 4 lay 5 percentage points below the measured number; the measured number falls inside the stated range.
By their numbers in this assay, from the lowest: compound 3; then compounds 4, 1 and 2 (each within the scatter of the next).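

In this assay, for the compounds shown here, the exchange of 3-(hydroxymethyl)phenyl for 2-chloropyridin-3-yl gives a number 7 percentage points lower from compound 2 to compound 4 (within the scatter), so this nitrogen of the five-membered aromatic ring with 3 nitrogen now has a measured exchange that stays inside the scatter, whereas the earlier compounds offered only the large step of a number 37 percentage points lower from compound 1 to compound 3 (beyond the scatter). The group that leaves has 1 hydrogen-bond donor and the group that enters has 0, and its six-membered aromatic ring carries 1 hetero atom, yet in this pair these differences come with no move beyond the scatter. No measurement shown here explains why the number holds across this exchange.

This single step changes the hydroxymethyl group, the ring nitrogen and the chlorine together, so it cannot say what each contributes, and a plain pyridin-3-yl or a 3-chlorophenyl group would be needed to pull them apart. It also leaves open how a carboxylic acid or an amine on the ring carried by this nitrogen would read in this assay.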